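Methyl to benzyl on a compound read only as a limit

A few compounds are considered here, and "the series" means these few. Any claim that something is new, unique, unknown or untested is made for them only; others in the source may bear on it.

In a functional assay on HUVEC cells (Homo sapiens) for inhibition, read by crystal violet staining, with a stated time of 72 h (on this read-out higher numbers stand for weaker inhibition of growth and lower numbers for stronger inhibition of growth), compound 1 (`COc1ccc(-c2cnn(C)c2-c2cc(OC)c(OC)c(OC)c2)cc1O`) gives a measured 68 nM as its result. Compound 2 (`COc1ccc(-c2cnn(Cc3ccccc3)c2-c2cc(OC)c(OC)c(OC)c2)cc1O`) gives > 2500 nM, which is a limit of the assay. Compound 3 (`COc1ccc(-c2cn(C)nc2-c2cc(OC)c(OC)c(OC)c2)cc1O`) gives > 5000 nM, also a limit, so it offers no exact number to start from. Compound 4 (`COc1ccc(-c2cn(Cc3ccccc3)nc2-c2cc(OC)c(OC)c(OC)c2)cc1O`) differs from compound 3 by phenyl in place of hydrogen on a saturated chain carbon bound to an aromatic nitrogen, the change from methyl to benzyl. Among the measured compounds shown here, the only measured step of this kind is an at least 36-fold higher number from compound 1 to compound 2 (1.56 log units; beyond the scatter), and it is a large move toward weaker inhibition of growth. Given that step, no gain is expected for compound 4 in this assay, and it should remain weak. The expected step is a step that the limit leaves unreadable from compound 3 to compound 4. For compound 4 the estimate is 6000 nM, with an expected range from 2000 nM to 20000 nM.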

Compound 4, concentration for 50% growth inhibition: > 5000 nM
Compound 4 was reported as a limit; the forecaster's own chance of this, stated with the estimate: 85%; the middle value is on the limit's open side.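

Compound 3 and compound 4 both stand as limits in this assay, so no step can be read between them: the limit of > 5000 nM in this assay, at which 2 of the 4 values shown sit.

As far as these compounds go, whether methyl to benzyl changes inhibition of growth between these two compounds stays open.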